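From a Cyclopropyl Amide to a Furan Amide

A few compounds are considered here, and "the series" means these few. Any claim that something is new, unique, unknown or untested is made for them only; others in the source may bear on it.

Compound 1 `CN1CCC(C(=O)N2Cc3c(NC(=O)C4CC4)n[nH]c3C2(C)C)CC1` is one of three amides built on a shared core. In a physicochemical assay for solubility, at pH 7 (a higher number here means a more soluble compound, a lower number a less soluble compound), compound 1 gives > 225000 nM, which is a limit of the assay rather than a number. Compound 2 `CN1CCC(C(=O)N2Cc3c(NC(=O)C4CCC4)n[nH]c3C2(C)C)CC1` gives > 225000 nM in this assay, again a limit. Compound 3 `CN(C)CC(=O)Nc1n[nH]c2c1CN(C(=O)C(C)(C)C)C2(C)C` gives > 225000 nM in this assay, also a limit. Within the data shown here, the only step between close neighbours, a step that the two limits leave unreadable from compound 1 to compound 2, cannot be sized because of the limit of > 225000 nM in this assay, at which 3 of the 3 values shown sit.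

Compound 4 `CN1CCC(C(=O)N2Cc3c(NC(=O)c4ccco4)n[nH]c3C2(C)C)CC1` differs from compound 1 in one place: furan-2-yl in place of cyclopropyl on a carbonyl carbon. Among the measured compounds shown here, no measured step carries this same change, and the one step that exists, cyclobutyl in place of cyclopropyl, is unreadable, so these numbers give no direction and no size for what the furan brings. With every measured compound sitting at the limit, compound 4 is expected to land at an estimate of 200000 nM, with a range from 50000 nM to 400000 nM. The step this estimate means, an at least 1.1-fold lower number from compound 1 to compound 4 (0.05 log units; that floor lies within the scatter), is expected to stay within the scatter.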

Compound 4, solubility: > 225000 nM
Compound 4: a limit, no number; the forecaster's own chance of this, stated with the estimate: 55%; middle value at least 1.1-fold (0.05 log units) away from the limit.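

Compound 4 gives > 225000 nM in this assay, which is a limit, so the steps to compound 4 from compound 1 and from compound 2 cannot be read: the limit of > 225000 nM in this assay, at which 4 of the 4 values shown sit.

The compounds shown leave open whether cyclopropyl, cyclobutyl or furan-2-yl on that carbonyl carbon makes any difference in this assay.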